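The source may report more compounds than this note shows. Statements on the series, on what has been measured and on what is new or still open speak of the compounds shown alone.

Notes on the series. The shared core is kept throughout; only the substituted aromatic ring on the carbon with a double bond to nitrogen is varied, and three variants have been run in a functional assay on U-251 cells (Homo sapiens) for inhibition, read by sulforhodamine B assay, with a stated time of 48 h; a lower number here means a stronger inhibitor of growth, a higher number a weaker inhibitor of growth. Compound 1 `CC1=CC[C@H](C(C)(C)NC(=S)N/N=C/c2ccc(O)cc2)CC1` gives > 100000 nM, which is a limit of the assay rather than a number. Compound 2 `CC1=CC[C@H](C(C)(C)NC(=S)N/N=C/c2ccccc2O)CC1` gives 6400 nM. Compound 3 `CC1=CC[C@H](C(C)(C)NC(=S)N/N=C/c2ccc(N(C)C)cc2)CC1` gives 57700 nM, the higher of the two numbers in hand, with compound 2 clearly lower.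

Two steps have been measured. Among the measured compounds shown here, the step of an at least 15-fold lower number from compound 1 to compound 2 (1.19 log units; beyond the scatter) moves the hydroxy group around the ring and is the only large step seen. The step of an at least 1.7-fold lower number from compound 1 to compound 3 (0.23 log units; that floor lies within the scatter) exchanges the group at the very position that compound 4 alters, and it has a floor only because of the limit of > 100000 nM in this assay, at which 1 of the 3 values shown sits; that floor lies within the scatter, so the exchange did little.

Compound 4 `CC1=CC[C@H](C(C)(C)NC(=S)N/N=C/c2ccc(F)cc2)CC1` differs from compound 3 by fluoro in place of dimethylamino on an aromatic carbon. For the measured compounds named here, the one step that bears on it, from compound 1 to compound 3, was small, so compound 4 is expected to stay near compound 3. The expected step of a 1.2-fold lower number from compound 3 to compound 4 (0.06 log units; within the scatter) is therefore not beyond the scatter. Compound 4 is estimated at 50000 nM, between 15000 nM and 150000 nM, with a fair chance that this assay again returns only a limit.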

Compound 4, concentration for 50% growth inhibition: > 100000 nM
Compound 4 ended at the assay's limit (the forecaster's own chance of this, stated with the estimate: 35%); middle value at least 2.0-fold (0.30 log units) from the limit.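

Of the groups placed para to a large group, fluoro in compound 4 joins hydroxy in compound 1 at the limit, so this position has now given two of its three variants without a number in this assay. Among the compounds shown here, the step of an at least 15-fold higher number from compound 2 to compound 4 (1.19 log units; beyond the scatter) is large and shows that compound 2 keeps its clear separation from the 4-fluorophenyl variant as well as from the 4-hydroxyphenyl variant, so within these four compounds 2-hydroxyphenyl alone gives a number well clear of the limit, with compound 3 the only other measured number. The step of an at least 1.7-fold higher number from compound 3 to compound 4 (0.23 log units; that floor lies within the scatter) offers only a floor within the scatter, because compound 4 stands at the limit, and the step between compound 1 and compound 4 cannot be read, as both values are limits: the limit of > 100000 nM in this assay, at which 2 of the 4 values shown sit.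

On these data alone, whether fluoro, hydroxy and dimethylamino truly differ at this position remains open, since the two limits hide how far compound 1 and compound 4 lie from compound 3. Also open, as far as these compounds go, is whether the gain of compound 2 depends on the hydroxy group itself, which a 2-methoxyphenyl, 2-fluorophenyl or 2-aminophenyl group on the shared core would help to settle.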